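Pyridinyl triazole on the bromophenol core: estimate for compound 4

The source may report more compounds than this note shows. Statements on the series, on what has been measured and on what is new or still open speak of the compounds shown alone.

Of the compounds shown here, three have been measured in a functional assay on SMMC-7721 cells (Homo sapiens) for cytotoxicity, read by MTT assay, with a stated time of 4 days; a higher number here means a weaker inhibitor, a lower number a stronger inhibitor. Compound 1 `C=C1C(=O)[C@]23C[C@@]1(O)CC[C@H]2c1ccc(OS(=O)(=O)c2ccc(C)cc2)c(C)c1[C@@H]3Cn1cc(-c2ccccn2)nn1` gives 2830 nM. Compound 2 `C=C1C[C@]23C[C@@]1(O)CC[C@H]2c1ccc(OS(=O)(=O)c2ccc(C)cc2)c(C)c1[C@@H]3Cn1cc(-c2ccc(Br)cc2)nn1` returns only a limit, > 20000 nM, not a number. Compound 3 `C=C1C[C@]23C[C@@]1(O)CC[C@H]2c1cc(Br)c(O)c(C)c1[C@@H]3Cn1cc(-c2ccc(OC)cc2)nn1` likewise returns only a limit, > 20000 nM, so its position in this assay is known solely as sitting at the limit of > 20000 nM in this assay, at which 2 of the 3 values shown sit. Going by the values given here, no two measured compounds differ in a single place, so no measured step is available.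

Compound 4 `C=C1C[C@]23C[C@@]1(O)CC[C@H]2c1cc(Br)c(O)c(C)c1[C@@H]3Cn1cc(-c2ccccn2)nn1` is not yet measured. It differs from compound 3 by pyridin-2-yl in place of 4-methoxyphenyl on an aromatic carbon. Among the compounds with values here, the pyridin-2-yl group also appears in compound 1, the only compound with a numeric value, 2830 nM, though compound 1 differs from compound 4 elsewhere as well. A modest step toward stronger inhibition is therefore expected, an at least 1.6-fold lower number from compound 3 to compound 4 (0.22 log units; that floor lies within the scatter), with real chance that only a limit is again reported. Compound 4 is estimated at 12000 nM, within a range of 3000 nM to 40000 nM.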

Compound 4, half-maximal inhibitory concentration: > 20000 nM
Compound 4 gave a limit, no number; the forecaster's own chance of this, stated with the estimate: 45%; middle value at least 1.6-fold (0.22 log units) from the limit.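

Compound 4 gives only a limit, > 20000 nM. Going by these compounds alone, compound 3 is also held at a limit, so no step between compound 3 and compound 4 can be read. The compounds shown leave open which of the differences between compound 1 and compound 4 accompanies the numeric value of compound 1.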